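Acyl variation on an aminopyrazole scaffold: toward pyridyl ketone

The source may report more compounds than this note shows. Statements on the series, on what has been measured and on what is new or still open speak of the compounds shown alone.

Measured compounds:
Compound 1: `CCC(=O)n1nc(C)c(-c2ccc(Cl)c(Cl)c2)c1N`, 27400 nM
Compound 2: `Cc1nn(C(=O)C2CC2)c(N)c1-c1ccc(Cl)c(Cl)c1`, 24300 nM
Compound 3: `Cc1nn(C(=O)C2CCCCC2)c(N)c1-c1ccc(Cl)c(Cl)c1`, 3300 nM

Three compounds share a core and differ only in the group on the carbonyl carbon. In an assay on Sf9 cells for inhibition of mitogen-activated protein kinase kinase kinase 14 (Homo sapiens), read by ADP-Glo, with a stated time of 60 min (on this read-out higher numbers stand for weaker inhibition and lower numbers for stronger inhibition), compound 1 gives 27400 nM, and compound 2 gives 24300 nM; the two differ by a 1.1-fold lower number from compound 1 to compound 2 (0.05 log units; within the scatter). Compound 3 gives 3300 nM, the lowest number of the three, and the two steps reaching it are an 8.3-fold lower number from compound 1 to compound 3 (0.92 log units; beyond the scatter) and a 7.4-fold lower number from compound 2 to compound 3 (0.87 log units; beyond the scatter).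

Compound 4, `Cc1nn(C(=O)c2ccncc2)c(N)c1-c1ccc(Cl)c(Cl)c1`, has not been measured in this assay. Its difference from compound 3 is pyridin-4-yl in place of cyclohexyl on a carbonyl carbon. The measured steps concern only saturated carbon groups of differing size on that carbonyl carbon; none of them exchanges a saturated ring for an aromatic ring bearing an acceptor, so they bear on this step only loosely. Going by these compounds, the ring size is kept, which matches the direction in which compound 3 improved on compound 2, but the aromatic character and the acceptor are untested here. A modest rise in the number is expected for compound 4, with wide uncertainty, the step being a 2.4-fold higher number from compound 3 to compound 4 (0.38 log units; beyond the scatter). Compound 4 is therefore estimated at 8000 nM, within a range from 1500 nM to 40000 nM.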

Compound 4, half-maximal inhibitory concentration: 58200 nM
For compound 4 the middle estimate is 7.3-fold (0.86 log units) below the measured one, and the stated range ends below it.
By their numbers in this assay, from the lowest: compound 3; then compounds 2 and 1 (each within the scatter of the next); then compound 4.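

In this assay, keeping a six-membered ring on the carbonyl carbon did not keep the gain seen with cyclohexyl: the exchange for pyridin-4-yl, with the same count of heavy atoms, gave an 18-fold higher number from compound 3 to compound 4 (1.25 log units; beyond the scatter). The change also took the number past those of the two small groups, with a 2.4-fold higher number from compound 2 to compound 4 (0.38 log units; beyond the scatter) and a 2.1-fold higher number from compound 1 to compound 4 (0.33 log units; beyond the scatter), so ring size alone does not set the number at this position, and compound 4 is the weakest of the four. No measurement at hand offers a reason for this step.

The compounds shown leave open whether the rise goes with the aromatic ring or with its nitrogen: phenyl on the carbonyl carbon would have the first without the second, and piperidin-4-yl the second without the first. Also open, going by these compounds, is how far the number follows the size of a saturated group, which only ethyl, cyclopropyl and cyclohexyl speak to here, and cyclopentyl or cycloheptyl would extend that series.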